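From compound 3 to compound 4: one ring swap

This account rests on a few compounds, and the source may have more. Where it says the series, first, only, none or still open, it means among the compounds named here.

In an in vitro ADME assay on microsomes from liver (Simiiformes) (on this read-out lower numbers stand for a shorter-lived compound and higher numbers for a longer-lived compound), compound 3 `Cc1ccc(CCCOc2c(C)cc(-c3noc(C(F)(F)F)n3)cc2C)cn1` gives 1.97 h and sits within the scatter of compound 2 `CC(=O)c1ccc(CCCOc2c(C)cc(-c3noc(C(F)(F)F)n3)cc2C)o1` with 1.05 h as its half-life. Compound 1 `CCc1cc(CCCOc2c(C)cc(-c3noc(C(F)(F)F)n3)cc2C)on1` shows > 2.5 h as a limit of the assay, not a number. Compound 4 `Cc1cc(-c2noc(C(F)(F)F)n2)cc(C)c1OCCCc1cccc(F)n1` is still unmeasured and carries 6-fluoropyridin-2-yl in place of 6-methylpyridin-3-yl on a saturated chain carbon (6-fluoropyridin-2-yl in place of 6-methylpyridin-3-yl on a saturated chain carbon, three bonds along the chain from an oxygen on an aromatic ring). Three measured swaps at that same place bear on it: an at least 2.3-fold lower number from compound 1 to compound 2 (0.37 log units; beyond the scatter) lies modestly beyond the scatter, while a 1.9-fold higher number from compound 2 to compound 3 (0.27 log units; within the scatter) lies within it and an at least 1.2-fold lower number from compound 1 to compound 3 (0.10 log units; that floor lies within the scatter) has a floor within it. Only a small change is therefore expected, with a 1.2-fold lower number from compound 3 to compound 4 (0.06 log units; within the scatter) estimated to stay within the scatter. Compound 4 is expected near 1.7 h (estimated range 0.9 h to 3 h).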

Compound 4, half-life: > 2.5 h
Compound 4: a limit, no number; the forecaster's own chance of this, stated with the estimate: 20%; middle value at least 1.4-fold (0.16 log units) away from the limit.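

In this assay compound 4, with 6-fluoropyridin-2-yl on this chain carbon, gives > 2.5 h, which is a limit of the assay. The swap shows an at least 1.2-fold higher number from compound 3 to compound 4 (0.10 log units; that floor lies within the scatter), so a real rise over 6-methylpyridin-3-yl is not shown, while an at least 2.3-fold higher number from compound 2 to compound 4 (0.37 log units; beyond the scatter) clearly favours 6-fluoropyridin-2-yl over 5-acetylfuran-2-yl. The step between compound 1 and compound 4 cannot be read, as both stand at the same limit: the limit of > 2.5 h in this assay, at which 2 of the 4 values shown sit.

As far as these compounds go, how far compound 4 lies past its limit stays open. So does how a plain phenyl ring or 6-methylpyridin-2-yl would read at this place.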